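From cyclobutylcarbonyl to propylcarbamoyl on the shared core

This account rests on a few compounds, and the source may have more. Where it says the series, first, only, none or still open, it means among the compounds named here.

In a functional assay on A2780 cells (Homo sapiens) for antiproliferative activity, read by fluorescence, with a stated time of 72 h (on this read-out higher numbers stand for weaker inhibition and lower numbers for stronger inhibition), compound 1 `CN1CCC(C(=O)N2Cc3c(NC(=O)C4CCC4)n[nH]c3C2(C)C)CC1` gives 140 nM, the lowest number among the three compounds measured. Compound 2 `CC1(C)c2[nH]nc(NC(=O)c3ccc(F)cc3)c2CN1C(=O)C1CCN(C2CC2)CC1` gives 380 nM in this assay, and compound 3 `CCN1CCC(C(=O)N2Cc3c(NC(=O)CC(C)C)n[nH]c3C2(C)C)CC1` gives 410 nM; both lie beyond the scatter from compound 1, so compound 1 stands as the most potent of the three measured. Going by the values given here, no two measured compounds differ in a single place, so no step can be read directly within the measured set.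

Compound 4 `CCCNC(=O)Nc1n[nH]c2c1CN(C(=O)C1CCN(C)CC1)C2(C)C` has not yet been measured. It differs from compound 1 in one place: propylamino in place of cyclobutyl on a carbonyl carbon. The four-membered ring of carbon only gives way to an open chain with one hydrogen-bond donor, turning the (cyclobutylcarbonyl)amino into a (propylcarbamoyl)amino.

Among the compounds with values here, no measured pair shows a change of this kind, so the size of the step rests on the structural change alone. A small weakening, at or just beyond the scatter, is expected; the estimated step from compound 1 to compound 4 is a 2.0-fold higher number from compound 1 to compound 4 (0.30 log units; within the scatter). Compound 4 is expected to give about 280 nM in this assay, within a range from 110 nM to 750 nM.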

Compound 4, half-maximal inhibitory concentration: 650 nM
Estimate against measurement, compound 4: 2.3-fold (0.37 log units) below; the range from low to high includes it.
By their numbers in this assay, from the lowest: compound 1; then compounds 2, 3 and 4 (each within the scatter of the next).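

The first step readable in this series falls on a carbonyl carbon: in this assay, propylamino in place of cyclobutyl gives a 4.6-fold higher number from compound 1 to compound 4 (0.67 log units; beyond the scatter), which lies beyond the scatter, so this position does not accept the change without a weakening. Both groups hold 4 heavy atoms, so the step does not come with a change in that count; what changes is that a four-membered ring of carbon only gives way to an open chain carrying a nitrogen and one hydrogen-bond donor, turning the (cyclobutylcarbonyl)amino into a (propylcarbamoyl)amino. No measurement at hand accounts for the size of this step.

The ring opening and the entry of the nitrogen arrive together in this single step, so the compounds shown leave open which of them carries the weakening, or whether both contribute. On the same carbonyl carbon, a butyl chain would show the open chain without the nitrogen, and a cyclobutylamino group would show the nitrogen with the ring kept.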